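A methyl on an aromatic nitrogen of compound 1

The source may report more compounds than this note shows. Statements on the series, on what has been measured and on what is new or still open speak of the compounds shown alone.

In a functional assay on K562 cells (Homo sapiens) for antiproliferative activity, read by MTT assay, with a stated time of 48 h (on this read-out higher numbers stand for weaker inhibition and lower numbers for stronger inhibition), compound 1 `CN(C)CCCn1c(N)c(-c2nc3ccccc3[nH]2)c2nc(C#N)c(C#N)nc21` gives 1730 nM and compound 2 `CN1CCN(CCCn2c(N)c(-c3nc4ccccc4[nH]3)c3nc(C#N)c(C#N)nc32)CC1` gives 1260 nM so the two lie within the scatter of each other. Compound 3 `N#Cc1nc2c(-c3nc4ccccc4[nH]3)c(N)n(CCCO)c2nc1C#N` gives > 50000 nM as a limit of the assay. Compound 4 `CN(C)CCCn1c(N)c(-c2nc3ccccc3n2C)c2nc(C#N)c(C#N)nc21` differs from compound 1 by methyl in place of hydrogen on an aromatic nitrogen. Going by the values given here, no measured step touches that nitrogen. Changes at the chain end gave a 1.4-fold lower number from compound 1 to compound 2 (0.14 log units; within the scatter) in one case and an at least 28-fold higher number from compound 1 to compound 3 (1.46 log units; beyond the scatter) in the other, so they show only that a single change in this series may matter greatly or hardly at all. A modest rise in the number is therefore expected, with a 1.7-fold higher number from compound 1 to compound 4 (0.24 log units; within the scatter) as the estimated step. In this assay the expected value for compound 4 is 3000 nM with an estimated range from 800 nM to 15000 nM for the coming measurement.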

Compound 4, half-maximal inhibitory concentration: 3560 nM
Beside the measured number, compound 4's estimate is 1.2-fold (0.07 log units) below it, and the stated range covers the measured number.
By their numbers in this assay, from the lowest: compounds 2 and 1 (each within the scatter of the next); then compound 4. At a limit, above all of these: compound 3.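

Going by these compounds alone, the 1H-benzimidazol-2-yl to 1-methyl-1H-benzimidazol-2-yl change gives a 2.1-fold higher number from compound 1 to compound 4 (0.31 log units; beyond the scatter) in this assay, the first evidence that this aromatic nitrogen affects the read-out at all. The effect is modest, and compound 4 still gives a measured number rather than a limit of the assay, so the hydrogen on this nitrogen is not strictly needed for activity. Nothing shown here explains the step. On these data alone, it remains open whether an ethyl or benzyl group on this nitrogen would raise the number further, and whether methyl would shift compound 2 similarly.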